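Methyl groups replace chlorine on the phenoxyacetamide side chain

This account rests on a few compounds, and the source may have more. Where it says the series, first, only, none or still open, it means among the compounds named here.

Of the compounds shown here, three sharing one core have been measured in an assay on HEK293 cells for displacement of a labelled ligand from Melanocortin receptor 4 (Homo sapiens); a lower number here means a stronger inhibitor, a higher number a weaker inhibitor. Compound 1 `CC(C)C[C@H](N)c1cc(C(F)(F)F)ccc1N1CCN(C(=O)COc2ccc3ccccc3c2)CC1` gives 2000 nM. Among the measured compounds shown here, compound 2 `CC(C)C[C@H](N)c1cc(C(F)(F)F)ccc1N1CCN(C(=O)C(C)Cc2ccc(Cl)c(Cl)c2)CC1` gives 120 nM; 1600 nM (2 entries) and is the one compound reported more than once; its spread is visible in the several entries of compound 2 in this assay, 120 nM; 1600 nM (2 entries). Compound 3 `CC(C)C[C@H](N)c1cc(C(F)(F)F)ccc1N1CCN(C(=O)COc2ccc(Cl)cc2)CC1` gives 2900 nM, the highest of the two single numbers; its nearest neighbour is compound 1, and the step of a 1.5-fold higher number from compound 1 to compound 3 (0.16 log units; within the scatter) stays within the scatter.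

Compound 4 `Cc1ccc(OCC(=O)N2CCN(c3ccc(C(F)(F)F)cc3[C@@H](N)CC(C)C)CC2)c(C)c1` is not yet measured. It differs from compound 3 in one place: 2,4-dimethylphenyl in place of 4-chlorophenyl on an oxygen on a saturated carbon. For the measured compounds named here, no measured step touches this particular exchange. Going by the values given here, the only step on the same oxygen, a 1.5-fold higher number from compound 1 to compound 3 (0.16 log units; within the scatter), swapped one aryl group for another and moved the number by less than the scatter. The two entries of compound 2 show how far repeat measurements on this core can drift even without a structural change. On that basis the step from compound 3 to compound 4 is expected to be small, a 1.2-fold lower number from compound 3 to compound 4 (0.06 log units; within the scatter), with no direction beyond the scatter.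

Compound 4 is therefore estimated at 2500 nM in this assay, with a range from 800 nM to 8000 nM.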

Compound 4, inhibition constant: 4000 nM
Compound 4: the middle estimate sits 1.6-fold (0.20 log units) below what was measured; the range from low to high includes it.
By their numbers in this assay, from the lowest: compounds 1, 3 and 4 (each within the scatter of the next).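

In this assay, putting 2,4-dimethylphenyl in place of 4-chlorophenyl on this oxygen removes the chlorine and adds two methyl groups, yet the step stays within the scatter: a 1.4-fold higher number from compound 3 to compound 4 (0.14 log units; within the scatter). Among the compounds shown here, the aryl group at this position now appears in three forms, naphthalen-2-yl, 4-chlorophenyl and 2,4-dimethylphenyl, and the step between the first and third, a 2.0-fold higher number from compound 1 to compound 4 (0.30 log units; within the scatter), also stays within the scatter, so no pair among compounds 1, 3 and 4 can be put in order. Steps this small have to be read against the repeat entries on a related compound, which lie further apart than any of these steps: the several entries of compound 2 in this assay, 120 nM; 1600 nM (2 entries)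

The compounds shown leave open whether an aryl group carrying a carboxylic acid or an amine on this oxygen would move the number beyond the scatter. They also do not separate the contributions of the two methyl groups of 2,4-dimethylphenyl, which a single-methyl group such as 4-methylphenyl could address.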